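From carboxy to (diethylamino)methyl on the shared core

The compounds below may be only part of what the source reports. "The series", "measured", "known", "first", "only" and "open" are said of these compounds alone.

Compound 3 `CC(C)=CCC[C@]1(C)/C=C/[C@@H](OC(=O)C=C(C)C)[C@](C)(O)/C=C/C(=O)/C(C(=O)O)=C\C1` reaches only a limit in a functional assay on A549 cells (Homo sapiens) for antiproliferative activity, read by MTT assay, with a stated time of 48 h (on this read-out higher numbers stand for weaker inhibition and lower numbers for stronger inhibition), which is > 10000 nM. In this assay compound 1 `CC(=O)O[C@]1(C)/C=C/C(=O)/C(CO)=C\C[C@](C)(CCC=C(C)C)/C=C/[C@H]1OC(=O)C=C(C)C` gives 3150 nM, and compound 2 `CO[C@]1(C)/C=C/C(=O)/C(CO)=C\C[C@](C)(CCC=C(C)C)/C=C/[C@H]1OC(=O)C=C(C)C` gives 14400 nM. Compound 4 `CCN(CC)C/C1=C/C[C@](C)(CCC=C(C)C)/C=C/[C@@H](OC(=O)C=C(C)C)[C@](C)(O)/C=C/C1=O` differs from compound 3 as follows: (diethylamino)methyl in place of carboxy on a double-bonded ring carbon. Within the data shown here, the only measured step, a 4.6-fold higher number from compound 1 to compound 2 (0.66 log units; beyond the scatter), is a different change, methyl in place of acetyl on an oxygen on a saturated carbon, so it guides only the size expected, which is modest. Among the measured compounds shown here, a lower number is expected, since compound 3, the only compound with carboxy, holds the limit > 10000 nM. The expected step is an at least 2.0-fold lower number from compound 3 to compound 4 (0.30 log units; that floor lies within the scatter). For compound 4 the estimate is 5000 nM, with an expected range from 1500 nM to 16000 nM.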

Compound 4, half-maximal inhibitory concentration: 130 nM
Compound 4: the middle estimate sits 38-fold (1.59 log units) above what was measured, and the stated range ends above it.
By their numbers in this assay, from the lowest: compound 4; then compound 1; then compound 2.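

In this assay, the double-bonded ring carbon proved a highly responsive position: replacing carboxy with (diethylamino)methyl gives an at least 76-fold lower number from compound 3 to compound 4 (1.88 log units; beyond the scatter). Among these compounds, the only earlier step, a 4.6-fold higher number from compound 1 to compound 2 (0.66 log units; beyond the scatter), involved a different change at another place and was modest, whereas this one is large. Its true size remains unknown, as compound 3 has only a limit, not a number: the limit of > 10000 nM in this assay, at which 1 of the 4 values shown sits.

The compounds shown leave open whether a smaller dimethylaminomethyl group or a cyclic amine such as piperidin-1-ylmethyl at this carbon would give a similar number. They also leave open whether the nitrogen itself matters, which a plain propyl chain there could test.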